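The compounds below may be only part of what the source reports. "The series", "measured", "known", "first", "only" and "open" are said of these compounds alone.

Three compounds were tested in a functional assay on PC-3 cells (Homo sapiens) for antiproliferative activity, read by MTT assay, with a stated time of 48 h (on this read-out lower numbers stand for stronger inhibition and higher numbers for weaker inhibition), and a fourth, compound 4 `Cc1ccc2nc(Nc3ccnc(Nc4ccc(S(C)(=O)=O)cc4)n3)sc2c1`, awaits measurement there. Compound 2 `NS(=O)(=O)c1ccc(Nc2ncc(F)c(Nc3nc4ccccc4s3)n2)cc1` gives only a limit of the assay in this assay, > 50000 nM, and that value is a limit rather than a number. Compound 1 `Cc1ccc2nc(Nc3nc(Nc4ccc(S(N)(=O)=O)cc4)ncc3F)sc2c1` differs from compound 2 by a single change, (methyl in place of hydrogen on an aromatic carbon), and in this assay compound 1 gives 4960 nM. The step of an at least 10-fold lower number from compound 2 to compound 1 (1.00 log units; beyond the scatter) can be stated only as a lower bound because the limit of > 50000 nM in this assay, at which 1 of the 3 values shown sits, caps what was seen for compound 2. Compound 3 `CS(=O)(=O)c1ccc(Nc2nccc(Nc3nc4ccccc4s3)n2)cc1` carries a different core; how the two cores differ is not broken down here. In this assay compound 3 gives 1710 nM. Compound 4 differs from compound 3 by the same change, (methyl in place of hydrogen on an aromatic carbon), placed at the same spot on the shared fused ring. Compound 3 already sits at 1710 nM. The step from compound 2 to compound 1 is known only as a minimum. A smaller step is estimated here, at a 3.8-fold lower number from compound 3 to compound 4 (0.58 log units; beyond the scatter). Compound 4 is therefore expected to give about 450 nM, with a likely range from 120 nM to 1700 nM.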

Compound 4, half-maximal inhibitory concentration: > 50000 nM
Compound 4 gave a limit, no number; the forecaster's own chance of this, stated with the estimate: 3%; middle value at least 110-fold (2.04 log units) from the limit.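

In this assay, methyl in place of hydrogen on an aromatic carbon gives an at least 29-fold higher number from compound 3 to compound 4 (1.46 log units; beyond the scatter), and since compound 4 reaches only a limit of the assay, that step is a minimum and not an exact size. Set beside the earlier step, the same change does not carry over from one core to the other, as the two steps run in opposite directions: the same change on two cores in this assay, an at least 10-fold lower number (1.00 log units; beyond the scatter) from compound 2 to compound 1 and an at least 29-fold higher number (1.46 log units; beyond the scatter) from compound 3 to compound 4, at least 290-fold (2.46 log units) apart, beyond the scatter of two such steps In these two pairs, then, the outcome of adding the methyl depends on the core, but two pairs set no general rule, the cores differ in more than one place, and neither step has a known full size, with each resting on a limit: the limit of > 50000 nM in this assay, at which 2 of the 4 values shown sit.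

The compounds shown leave open which difference between the cores decides the direction of the step, the fluorine or the swap between sulfonamide and methyl sulfone. They also leave open whether ethyl or methoxy on the same aromatic carbon would follow the methyl on either core.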